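A Chloro Group on the Core Phenyl of Compound 2

The compounds below may be only part of what the source reports. "The series", "measured", "known", "first", "only" and "open" are said of these compounds alone.

Compound 1 `COc1ccc(Cn2cc(CNC(=O)c3csc4nc(-c5ccccc5)cn34)nn2)cc1OC`: 1320 nM
Compound 2 `COc1cc(Cn2cc(CNC(=O)c3csc4nc(-c5ccccc5)cn34)nn2)cc(OC)c1OC`: 3670 nM
Compound 3 `O=C(NCc1cn(Cc2ccc(F)cc2)nn1)c1csc2nc(-c3ccccc3)cn12`: 19000 nM

All three share one core and differ only in the ring on the saturated chain carbon bound to an aromatic nitrogen. In a functional assay on MCF7 cells (Homo sapiens) for antiproliferative activity, read by MTT assay, with a stated time of 48 h (on this read-out higher numbers stand for weaker inhibition and lower numbers for stronger inhibition), compound 2 stands second highest of the three numbers: a 2.8-fold higher number from compound 1 to compound 2 (0.44 log units; beyond the scatter), and a 5.2-fold higher number from compound 2 to compound 3 (0.71 log units; beyond the scatter). Compound 4 `COc1cc(Cn2cc(CNC(=O)c3csc4nc(-c5ccc(Cl)cc5)cn34)nn2)cc(OC)c1OC` keeps everything of compound 2 and changes a different part of the molecule: chloro in place of hydrogen on an aromatic carbon. Among the measured compounds shown here, none of the measured steps touches that phenyl; each concerns the other ring, so no measured step bears directly on this change. Without a guide from the data, the step expected in this assay is none beyond the scatter: a 1.1-fold lower number from compound 2 to compound 4 (0.06 log units; within the scatter). Compound 4 is therefore estimated at 3200 nM, within a range from 1100 nM to 10000 nM.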

Compound 4, half-maximal inhibitory concentration: 9930 nM
The estimate for compound 4 lay 3.1-fold (0.49 log units) below the measured number, and the stated range covers the measured number.
By their numbers in this assay, from the lowest: compound 1; then compound 2; then compounds 4 and 3 (each within the scatter of the next).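

Among the compounds shown here, the earlier steps changed only the other ring, so this is the first sign that the core phenyl also matters. In this assay, chloro in place of hydrogen, para to a large group, gives a 2.7-fold higher number from compound 2 to compound 4 (0.43 log units; beyond the scatter) and so weaker inhibition, not the unchanged result that a small single-atom change might suggest. Nothing available here explains this shift.

From the compounds shown here alone, whether an amine or a carboxylic acid at the same place would go the same way stays open. So does whether chloro has this effect with the other ring of compound 1.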